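This account rests on a few compounds, and the source may have more. Where it says the series, first, only, none or still open, it means among the compounds named here.

Measured compounds:
- compound 1 `O=C(Nc1ncc(Cc2ccc(F)cc2)s1)c1ccc(Cl)cc1Cl`, > 50000 nM in an ADME assay on HepG2 2.2.15 cells (Homo sapiens) for cytotoxicity; on this read-out lower numbers stand for higher toxicity in this test and higher numbers for lower toxicity in this test
- compound 2 `CC(C)(C)OC(=O)Nc1ncc(C(Oc2ccc(Br)cc2)c2ccc(Cl)cc2)s1`, > 50000 nM in this assay
- compound 3 `CCOC(=O)CCCNc1ncc(C(Oc2ccc3cc(Br)ccc3c2)c2ccc(Cl)cc2)s1`, "not toxic" (no number reported) in this assay

The series shares a thiazole-based core carrying a substituted amine and a diaryl side chain. In this assay compound 1 reaches only the limit of the test, > 50000 nM. In this assay compound 2 likewise stops at the limit, > 50000 nM. Compound 3 has no single number at all in this assay; it is reported simply as "not toxic" (no number reported), and so it stands beside the two other entries as a third compound without a measurable toxic concentration. The whole set is thus defined by the limit of > 50000 nM in this assay, at which 2 of the 3 values shown sit, with no ordering possible among its members.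

Compound 4 `O=C(Nc1ncc(C(Oc2ccc3cc(Br)ccc3c2)c2ccc(Cl)cc2)s1)C1CCCO1` differs from compound 3 only at the amine: (oxolan-2-yl)carbonyl in place of 3-(ethoxycarbonyl)propyl on a nitrogen on an aromatic ring. The rest of the molecule, the bromonaphthyloxy and chlorophenyl arms on the shared core, is unchanged. Among the compounds with values here, with every measured compound at or beyond the limit of this assay, no step can be sized, and nothing in the set points toward a change in either direction. Compound 4 is therefore expected to behave like its neighbours, with an estimated value of 60000 nM in this assay, ranging from 30000 nM to 150000 nM, and most likely reported as a limit rather than a number.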

Compound 4, half-maximal cytotoxic concentration: "not toxic" (no number reported)
For compound 4 the study gives words and no number, and the estimate cannot be compared.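

Compound 3 and compound 4 are both reported in this assay in words only, as not toxic, so no step can be read from the change of 3-(ethoxycarbonyl)propyl to (oxolan-2-yl)carbonyl. The compounds shown leave open at what concentration, if any, a member of this set would become toxic, since the values stop here: the limit of > 50000 nM in this assay, at which 2 of the 4 values shown sit.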